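The source may report more compounds than this note shows. Statements on the series, on what has been measured and on what is new or still open speak of the compounds shown alone.

Measured in a functional assay on HepG2 cells (Homo sapiens) for antiproliferative activity, read by MTT assay, with a stated time of 48 h; a lower number here means a stronger inhibitor, a higher number a weaker inhibitor:
- Compound 1 `CCn1c(C(=O)NCCCN(C)C)ccc1C(CC)(CC)c1ccc(OCCC(O)(CC)CC)c(C)c1`: 110 nM
- Compound 2 `CCn1c(C(=O)N(CCC#N)CCC#N)ccc1C(CC)(CC)c1ccc(OCCC(O)(CC)CC)c(C)c1`: 46300 nM
- Compound 3 `C#CC(C)OC(=O)c1ccc(C(CC)(CC)c2ccc(OCCC(O)(CC)CC)c(C)c2)n1CC`: > 50000 nM (a limit, not a number)

Compound 3 gives only a limit of the assay: > 50000 nM. Its place on these numbers is the limit of > 50000 nM in this assay, at which 1 of the 3 values shown sits.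

The next compound, compound 4 `CCOC(=O)CN(C)C(=O)c1ccc(C(CC)(CC)c2ccc(OCCC(O)(CC)CC)c(C)c2)n1CC`, keeps the shared core of compound 3 and alters one group. On a carbonyl carbon whose other neighbour is an aromatic carbon, ((ethoxycarbonyl)methyl)(methyl)amino takes the place of (1-methylprop-2-yn-1-yl)oxy: ((ethoxycarbonyl)methyl)(methyl)amino in place of (1-methylprop-2-yn-1-yl)oxy on a carbonyl carbon.

Three measured steps changed this same group. Two are large: a 420-fold higher number from compound 1 to compound 2 (2.62 log units; beyond the scatter), and an at least 450-fold higher number from compound 1 to compound 3 (2.65 log units; beyond the scatter). The third, an at least 1.0-fold higher number from compound 2 to compound 3 (0.03 log units; that floor lies within the scatter), does not go beyond the scatter. Among these compounds, only compound 1, with its (3-(dimethylamino)propyl)amino group, gives a low number.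

Compound 4 lacks that group, as does compound 2 at 46300 nM. No step beyond the scatter is therefore expected in this assay. The expected step is an at least 1.2-fold lower number from compound 3 to compound 4 (0.09 log units; that floor lies within the scatter). Compound 4 is estimated at 40000 nM, with an expected range from 15000 nM to 60000 nM.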

Compound 4, half-maximal inhibitory concentration: 25300 nM
Compound 4: the middle estimate sits 1.6-fold (0.20 log units) above what was measured; measured number inside the range.
By their numbers in this assay, from the lowest: compound 1; then compounds 4 and 2 (each within the scatter of the next). At a limit, above all of these: compound 3.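

The ester-bearing ((ethoxycarbonyl)methyl)(methyl)amino group gives this position a second group with a measured number far from that of compound 1 in this assay: a 230-fold higher number from compound 1 to compound 4 (2.36 log units; beyond the scatter). Two different groups on the carbonyl carbon, one with an ester and the other with two nitriles, do not separate, as this step stays within the scatter: a 1.8-fold lower number from compound 2 to compound 4 (0.26 log units; within the scatter). Among the four compounds, the low number therefore still belongs to compound 1 alone. The last change adds nothing firm, as its floor lies within the scatter: an at least 1.9-fold lower number from compound 3 to compound 4 (0.29 log units; that floor lies within the scatter). Compound 3 holds only a limit, not a number: the limit of > 50000 nM in this assay, at which 1 of the 4 values shown sits.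

What sets the (3-(dimethylamino)propyl)amino group apart remains open, as the compounds shown do not separate its terminal dimethylamino from its amide hydrogen or the length of its chain. From the compounds shown here alone, a plain propylamino group, a (2-(dimethylamino)ethyl)amino group or a methylated (3-(dimethylamino)propyl)(methyl)amino group on the same carbonyl carbon would each test one of these features, and a carboxylic acid in place of the ester of compound 4 is also open.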